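Removing the Hydroxy Group from Compound 3

This account rests on a few compounds, and the source may have more. Where it says the series, first, only, none or still open, it means among the compounds named here.

The measured compounds and their values:
Compound 1 `O=C1CC(c2ccccc2)=NCC2(CN3CCC2CC3)N1` gives 15% in an assay on cell membranes for displacement of a labelled ligand from Neuronal acetylcholine receptor; alpha4/beta2 (Rattus norvegicus), read by scintillation counting, with a stated time of 2 h, tested at 5 uM; on this read-out higher numbers stand for more inhibition at the one concentration tested (going by the name of the read-out) and lower numbers for less inhibition.
Compound 2 `COc1ccccc1C1=NCC2(CN3CCC2CC3)NC(=O)C1` gives 7% in this assay.
Compound 3 `Oc1c(C2=NC3(CN2)CN2CCC3CC2)oc2ccccc12` gives 32% in this assay.

Compound 3 stands highest of the three numbers; its nearest neighbour is compound 1, and its furthest is compound 2, both separated from it by more than the usual scatter. Compound 4 `c1ccc2oc(C3=NC4(CN3)CN3CCC4CC3)cc2c1` differs from compound 3 in one place: hydrogen in place of hydroxy on an aromatic carbon. Among the compounds with values here, only one measured step exists, a number 8 percentage points lower from compound 1 to compound 2 (within the scatter), and it concerns a different kind of change on a different ring, so it bears on the present step only loosely, showing that a small oxygen-bearing group on an aromatic carbon moved the read-out little. Within the data shown here, no measured pair shows what the loss of a hydroxy does. In this assay compound 4 is therefore expected to lie near compound 3, with a step of a number 7 percentage points lower from compound 3 to compound 4 (within the scatter) that stays within the scatter. The estimate for compound 4 is 25%, with a range from 5% to 45%.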

Compound 4, a percentage reported as inhibition, at one concentration (the size of the read-out at that concentration, not a potency): 4%
For compound 4 the middle estimate is 21 percentage points above the measured one; measured number outside the range, below it.
By their numbers in this assay, from the lowest: compounds 4, 2 and 1 (each within the scatter of the next, the first and the last beyond it); then compound 3.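

In this assay, within the data shown here, the hydroxy on the aromatic carbon of the five-membered aromatic ring carries weight: taking it away gives a number 28 percentage points lower from compound 3 to compound 4 (beyond the scatter) and is the first measured step of this kind. The earlier step, a number 8 percentage points lower from compound 1 to compound 2 (within the scatter) on a different ring, had shown only a change that stayed small, and it gave no sign that a single oxygen-bearing group could move the read-out this far. Nothing measured here gives a reason for the loss.

From the compounds shown here alone, whether an amine or a carboxylic acid at this place would hold the read-out as the hydroxy does, or lose it as hydrogen does, stays open. Going by these compounds, the read-out is taken at one concentration and is not a potency, and what this step would amount to as a potency stays open too.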